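This account rests on a few compounds, and the source may have more. Where it says the series, first, only, none or still open, it means among the compounds named here.

Measured compounds:
- compound 1, `CC1=NN(C(=O)c2ccc(C)cc2)C(c2cc(Br)ccc2O)C1`, 21000 nM
- compound 2, `CCN(CC)CC(=O)N1N=C(C)CC1c1ccccc1O`, 39800 nM
- compound 3, `CCC(=O)N1N=C(c2cc3ccccc3oc2=O)CC1c1ccccc1`, 5300 nM

In a functional assay on MGC-803 cells (Homo sapiens) for cytotoxicity, read by MTT assay, with a stated time of 48 h (on this read-out lower numbers stand for stronger inhibition and higher numbers for weaker inhibition), compound 3 gives the lowest of the three numbers shown, and its gap to each of the other two compounds lies beyond the usual scatter. Compound 4, `CN1CCN(CC(=O)N2N=C(c3cc4ccccc4oc3=O)CC2c2ccccc2)CC1`, has not yet been measured. It differs from compound 3 in one place: 4-methylpiperazin-1-yl in place of methyl on a saturated chain carbon bound to a carbonyl carbon. Among the measured compounds shown here, compound 2 also carries an amine on a chain near the carbonyl, but its core differs from that of compound 3, so no clean step is available to guide expectations. The change is therefore expected to give no step beyond the scatter, and compound 4 is estimated at 6000 nM, within 2000 nM to 18000 nM, a step of a 1.1-fold higher number from compound 3 to compound 4 (0.05 log units; within the scatter).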

Compound 4, half-maximal inhibitory concentration: 46100 nM
For compound 4 the middle estimate is 7.7-fold (0.89 log units) below the measured one, outside the stated range (above it).
By their numbers in this assay, from the lowest: compound 3; then compounds 1, 2 and 4 (each within the scatter of the next, the first and the last beyond it).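

In this assay, this place on a saturated chain carbon bound to a carbonyl carbon proves sensitive: 4-methylpiperazin-1-yl in place of methyl gives an 8.7-fold higher number from compound 3 to compound 4 (0.94 log units; beyond the scatter). Among the compounds shown here, this is the first step with only one place changed, so the loss of activity can be tied to this swap alone. No measurement here explains the loss. Open, on these data alone, is whether a smaller dimethylamino group, a morpholine ring or a longer plain chain at this place would keep the activity of compound 3 or lose it as well.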